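The source may report more compounds than this note shows. Statements on the series, on what has been measured and on what is new or still open speak of the compounds shown alone.

Compound 1 `COc1ccc(/C=C/C2CC(=O)C=CO2)cc1OC` and compound 2 `COc1cc(/C=C/C2CC(=O)C=CO2)cc(OC)c1OC` share one core; compound 3 `COc1ccc(/C=C/C2CC=CC(=O)O2)cc1OC` and compound 4 `COc1cc(OC)c(OC)cc1/C=C/C1CC=CC(=O)O1` share another, and the difference between the two cores is not broken down here. In a functional assay on HT-29 cells (Homo sapiens) for inhibition, read by sulforhodamine B assay, with a stated time of 48 h (on this read-out lower numbers stand for stronger inhibition of growth and higher numbers for weaker inhibition of growth), compound 1 gives 123 uM and compound 2 gives 135 uM; the change methoxy in place of hydrogen on an aromatic carbon made a 1.1-fold higher number from compound 1 to compound 2 (0.04 log units; within the scatter). Compound 3 gives 17.2 uM, the strongest inhibition of the three measured, beyond the scatter from both others. Compound 4 carries the same kind of change, (methoxy in place of hydrogen on an aromatic carbon), but the place differs: ortho to a group of 9 heavy atoms and para to a methoxy group, rather than ortho to a methoxy group and meta to that group. Resting on the flat step seen for compound 1 to compound 2, the expected step is a 1.1-fold higher number from compound 3 to compound 4 (0.04 log units; within the scatter), and compound 4 is estimated at 19 uM, between 8 uM and 45 uM.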

Compound 4, concentration for growth inhibition (reported as GI): 15.9 uM
Estimate against measurement, compound 4: 1.2-fold (0.08 log units) above, within the range that was stated.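

In this assay, methoxy in place of hydrogen on an aromatic carbon gave a 1.1-fold lower number from compound 3 to compound 4 (0.03 log units; within the scatter) on the core of compound 3, and the earlier step on the other core agrees with it: the same change on two cores in this assay, a 1.1-fold higher number (0.04 log units; within the scatter) from compound 1 to compound 2 and a 1.1-fold lower number (0.03 log units; within the scatter) from compound 3 to compound 4, 1.2-fold (0.07 log units) apart, within the scatter of two such steps. The change therefore carried from one core to the other without a step beyond the scatter on either, although its place on the aromatic ring differs. Among these compounds, both steps are flat and each core supplies only one pair, so this does not show that a change with a real effect would carry over in the same way.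

Open, on these data alone, is whether an amine or a carboxylic acid on the aromatic ring would shift growth inhibition on either core. Also open, as far as these compounds go, is whether a longer chain in place of methoxy would do so.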